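The source may report more compounds than this note shows. Statements on the series, on what has been measured and on what is new or still open speak of the compounds shown alone.

Measured compounds in a functional assay on MCF7 cells (Homo sapiens) for cytotoxicity, read by MTT assay, with a stated time of 72 h; on this read-out higher numbers stand for weaker inhibition and lower numbers for stronger inhibition:
compound 1 `CCOC(=O)C1=C(C)NC(=O)NC1c1cn(C(=O)CNc2ccc([N+](=O)[O-])cc2C)c2ccccc12` gives 50 ug/mL;
compound 2 `CCOC(=O)C1=C(C)NC(=S)NC1c1cn(C(=O)CNc2cccc([N+](=O)[O-])c2)c2ccccc12` gives a limit, > 1000 ug/mL;
compound 3 `CCOC(=O)C1=C(C)NC(=S)NC1c1cn(C(=O)CNc2ccc(Cl)cc2)c2ccccc12` gives 80 ug/mL.

Compound 1 has the lowest of the two numbers that were actually read; compound 3 sits near it, within the scatter, so the two cannot be ranked against each other. The value of compound 2 is only a limit of this assay (the limit of > 1000 ug/mL in this assay, at which 1 of the 3 values shown sits).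

Compound 4 `CCOC(=O)C1=C(C)NC(=O)NC1c1cn(C(=O)CNc2ccc(Cl)cc2)c2ccccc12` is the not-yet-measured partner of compound 1. The change is 4-chlorophenyl in place of 2-methyl-4-nitrophenyl on an amine nitrogen. Among the measured compounds shown here, one measured step bears on it: an at least 12-fold lower number from compound 2 to compound 3 (1.09 log units; beyond the scatter). On these data alone, that step also swapped a nitro-bearing phenyl for 4-chlorophenyl on the amine nitrogen, although the starting group there was 3-nitrophenyl rather than 2-methyl-4-nitrophenyl, and it started from a limit, so its true size is unknown. Compound 3 carries the same 4-chlorophenyl as compound 4 but differs from it elsewhere in the core, so it does not settle the matter.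

The expectation is therefore a step of a 1.1-fold lower number from compound 1 to compound 4 (0.05 log units; within the scatter) from compound 1, a small movement within the scatter. Compound 4 is estimated at 45 ug/mL, with a likely range from 20 ug/mL to 120 ug/mL.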

Compound 4, half-maximal inhibitory concentration: 200 ug/mL
Compound 4: middle estimate off by 4.4-fold (0.65 log units), on the low side, and the stated range ends below it.
By their numbers in this assay, from the lowest: compounds 1 and 3 (each within the scatter of the next); then compound 4. At a limit, above all of these: compound 2.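

In this assay, replacing 2-methyl-4-nitrophenyl with 4-chlorophenyl on this amine nitrogen gives a 4.0-fold higher number from compound 1 to compound 4 (0.60 log units; beyond the scatter), so on this core the 4-chlorophenyl group goes with weaker inhibition than the group it replaces. The earlier step that brought 4-chlorophenyl onto the same kind of nitrogen ran the other way, an at least 12-fold lower number from compound 2 to compound 3 (1.09 log units; beyond the scatter), which shows that this group does not lower the number in every setting, although that step left 3-nitrophenyl and took place on a different core. Compound 2, where that step starts, gives > 1000 ug/mL, which is a limit and not a number.

Nothing among the data shown explains why the number rises from compound 1 to compound 4. On these data alone, it remains open whether the methyl or the nitro group of 2-methyl-4-nitrophenyl matters more here, and a plain phenyl group, or an amine in place of the nitro group, on the same nitrogen would help to separate the two.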